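This account rests on a few compounds, and the source may have more. Where it says the series, first, only, none or still open, it means among the compounds named here.

Measured so far:
- Compound 1 `CC[C@H]1C[C@@H](c2c(OC)cccc2OC)N(Cc2ccc(OC(F)(F)F)cc2)C1=O`: 3610 nM
- Compound 2 `CN[C@@H]1C[C@@H](c2c(OC)cccc2OC)N(Cc2ccc(OC(F)(F)F)cc2)C1=O`: 5810 nM
- Compound 3 `COc1cccc(OC)c1[C@@H]1C[C@H](Cl)C(=O)N1Cc1ccc(OC(F)(F)F)cc1`: 41 nM

All three were tested in a functional assay on CHO cells for antagonist activity at Orexin receptor type 2 (Homo sapiens), read by FLIPR and calcium flux; on this read-out lower numbers stand for stronger inhibition and higher numbers for weaker inhibition. Compound 3 has the lowest number of the three, and the gap to each of the others is well beyond the scatter: compound 1 sits far higher, and compound 2 higher still. Within the data shown here, the one step that can be read directly is an 88-fold lower number from compound 1 to compound 3 (1.94 log units; beyond the scatter), a large change brought about by a small exchange on a saturated ring carbon of the shared core.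

Compound 4 `CN[C@H]1C[C@@H](c2c(OC)cccc2OC)N(Cc2ccc(OC(F)(F)F)cc2)C1=O` is the next compound, not yet measured. It differs from compound 3 in one place: methylamino in place of chloro on a saturated ring carbon. Compound 2 carries the same methylamino group on the same ring carbon, differing from compound 4 only in the arrangement at that carbon, and compound 2 gives 5810 nM in this assay. Taken with the step from compound 1 to compound 3, both measured points suggest that leaving the chloro behind costs a great deal in this assay, so compound 4 is expected to show a large rise, a 61-fold higher number from compound 3 to compound 4 (1.79 log units; beyond the scatter). The estimate for compound 4 is 2500 nM, with a range from 500 nM to 10000 nM.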

Compound 4, half-maximal inhibitory concentration: > 10000 nM
Compound 4 was reported as a limit; the forecaster's own chance of this, stated with the estimate: 10%; middle value at least 4.0-fold (0.60 log units) away from the limit.
By their numbers in this assay, from the lowest: compound 3; then compounds 1 and 2 (each within the scatter of the next). At a limit, above all of these: compound 4.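

In this assay compound 4 is reported only as a limit, > 10000 nM. At this saturated ring carbon, the change from chloro to methylamino gives an at least 240-fold higher number from compound 3 to compound 4 (2.38 log units; beyond the scatter), and the change from ethyl to methylamino gives an at least 2.7-fold higher number from compound 1 to compound 4 (0.44 log units; beyond the scatter), so methylamino in this arrangement falls short of both chloro and ethyl, and each of these steps is a floor, with the true gap possibly wider. The step between the two methylamino compounds is an at least 1.7-fold higher number from compound 2 to compound 4 (0.23 log units; that floor lies within the scatter), and because that floor lies within the scatter, this pair cannot yet show whether the arrangement at this carbon matters, even though it is the only thing that separates them: the fact that compounds 2 and 4 differ only in the configuration as drawn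

The compounds shown leave open whether the low number of compound 3 belongs to chloro alone or would also be reached with another small group at this carbon, such as fluoro, bromo or hydroxy. They also leave open how a chloro compound with the opposite arrangement at this carbon would read out, and they give no cause for the loss seen with methylamino.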